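The source may hold more compounds than are shown below. What is called first, only, known or untested is meant among the compounds shown, and "the series" means these compounds.

Measured compounds:
- compound 1 `C[C@@H]1C=C[C@H](C)N1c1ccc(-c2cccc(Cl)c2Cl)nn1` gives 8.7 mL.min-1.g-1 in an in vitro ADME assay on microsomes from liver (Rattus norvegicus) for metabolic stability; on this read-out higher numbers stand for fast clearance and lower numbers for slow clearance
- compound 2 `C[C@@H]1CC[C@H](C)N1c1ccc(-c2cccc3cccnc23)nn1` gives 6 mL.min-1.g-1 in this assay
- compound 3 `C[C@@H]1CC[C@H](C)N1c1ccc(-c2cncc3ccccc23)nn1` gives 3.7 mL.min-1.g-1 in this assay

Among these three numbers compound 1 stands highest. Its nearest neighbour is compound 2, whose number is lower by an amount that stays within the usual scatter of repeated measurements, so the two cannot be told apart. Compound 3 sits furthest from compound 1, and that gap does lie beyond the scatter.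

The step under consideration leads from compound 1 to compound 4 `Clc1cccc(-c2ccc(N3CCCCC3)nn2)c1Cl`, which has not yet been measured in this assay. The structural change is this: a group of 6 heavy atoms (5 carbon, 1 nitrogen; one six-membered non-aromatic ring with 1 hetero atom) in place of a group of 7 heavy atoms (6 carbon, 1 nitrogen; one five-membered non-aromatic ring with 1 hetero atom), on an aromatic carbon. Both groups carry one hydrogen-bond acceptor and no donor, and neither carries a net charge; the group that leaves has two defined stereocentres and a double bond outside aromatic rings, while the group that enters has none of these.

Among the compounds with values here, no directly comparable step between measured compounds is available, so the size of the change in this assay is uncertain. Because compound 1 already gives 8.7 mL.min-1.g-1, compound 4 is expected to stay close to it, with the estimate for compound 4 at 10 mL.min-1.g-1, between 5 mL.min-1.g-1 and 20 mL.min-1.g-1, meaning an expected step of a 1.1-fold higher number from compound 1 to compound 4 (0.06 log units; within the scatter) that would not clear the scatter.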

Compound 4, intrinsic clearance in microsomes: 35 mL.min-1.g-1
For compound 4 the middle estimate is 3.5-fold (0.54 log units) below the measured one; the whole stated range lies below it.
By their numbers in this assay, from the lowest: compounds 3, 2 and 1 (each within the scatter of the next, the first and the last beyond it); then compound 4.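

In this assay, within the data shown here, putting piperidin-1-yl on the aromatic carbon next to the ring nitrogen, with the rest of compound 1 kept, gives a 4.0-fold higher number from compound 1 to compound 4 (0.60 log units; beyond the scatter) and provides the first comparison of compounds that differ in one place. It shows that the read-out responds to the group at this position, by a modest amount that lies beyond the scatter. The exchange alters several things at once, as the ring goes from five-membered to six-membered, the double bond outside aromatic rings and both defined stereocentres disappear, and the hydrogen-bond counts and the absence of net charge stay the same, but nothing available explains the rise in clearance.

The compounds shown leave open which of these differences carries the step, and whether a step of this size would recur on a different core. Going by these compounds, how a pyrrolidin-1-yl or a morpholin-4-yl group on the same aromatic carbon would read also remains open, and either group would help to separate ring size from the loss of the stereocentres and the double bond.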